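The compounds below may be only part of what the source reports. "The series", "measured", "known", "first", "only" and "open" are said of these compounds alone.

Compounds measured so far:
compound 1 `NC(=O)c1ncn(C2O[C@H](CO)[C@@H](O)[C@H]2O)c1C#CCO` gives 0.7 ug/mL
compound 2 `C#Cc1c(C#N)ncn1C1O[C@H](CO)[C@@H](O)[C@H]1O` gives 1.9 ug/mL

Not yet measured:
compound 3 `N#Cc1ncn(C2O[C@H](CO)[C@@H](O)[C@H]2O)c1C#CCO`

In a functional assay on L1210 cells (Mus musculus) for inhibition (on this read-out higher numbers stand for weaker inhibition and lower numbers for stronger inhibition), compound 2 has the higher of the two numbers, 1.9 ug/mL in all, and its gap to compound 1 lies beyond the usual scatter. Compound 3 is compound 2 with one change: hydroxymethyl in place of hydrogen on a triple-bonded carbon. This turns ethynyl into 3-hydroxyprop-1-yn-1-yl. Within the data shown here, no measured pair shows this change alone, so its size is uncertain. Compound 1 carries the same 3-hydroxyprop-1-yn-1-yl group and gives 0.7 ug/mL in this assay, yet it differs from compound 3 elsewhere. A modest move toward a higher number, meaning weaker inhibition, is expected, though no change beyond the scatter remains possible. The expected step is a 2.1-fold higher number from compound 2 to compound 3 (0.32 log units; beyond the scatter) on this estimate. For compound 3 the estimated value is 4 ug/mL within a range of 1.2 ug/mL to 15 ug/mL in this assay.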

Compound 3, half-maximal inhibitory concentration: 4.1 ug/mL
The estimate for compound 3 lay 1.0-fold (0.01 log units) below the measured number; the range from low to high includes it.
By their numbers in this assay, from the lowest: compound 1; then compound 2; then compound 3.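

In this assay, among these compounds, the step from ethynyl to 3-hydroxyprop-1-yn-1-yl can now be read directly for the first time: hydroxymethyl in place of hydrogen on a triple-bonded carbon gives a 2.2-fold higher number from compound 2 to compound 3 (0.33 log units; beyond the scatter) and so goes with weaker inhibition when cyano is kept constant. With 3-hydroxyprop-1-yn-1-yl kept constant instead, cyano in place of carbamoyl on an aromatic carbon gives a 5.9-fold higher number from compound 1 to compound 3 (0.77 log units; beyond the scatter) in the same direction, so the stronger inhibition of compound 1 cannot be credited to the 3-hydroxyprop-1-yn-1-yl group alone. Nothing measured here explains why either change shifts the number.

The compounds shown give the hydroxymethyl change only alongside cyano, so its size alongside carbamoyl remains open. From the compounds shown here alone, whether an amine in place of the hydroxyl, or a longer chain, would move the number in the same direction also remains open.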